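Amide Variation and Tolerability in a Monocytic Cell Line

A few compounds are considered here, and "the series" means these few. Any claim that something is new, unique, unknown or untested is made for them only; others in the source may bear on it.

Compound 1 `COc1ccc(-c2cnc(NC(=O)C3CCNCC3)n2C)cc1` — in a toxicity assay on THP-1 cells (Homo sapiens) for inhibition (a lower number here means that less compound is tolerated, a higher number that more compound is tolerated), compound 1 gives > 100000 nM, a limit of the assay.
Compound 2 `COc1ccc(-c2cnc(NC(=O)c3cnco3)n2C)cc1` — in this assay compound 2 gives > 100000 nM, likewise a limit.
Compound 3 `COc1ccc(-c2cnc(NC(=O)c3ccc(C)cc3)n2C)cc1` — in this assay compound 3 gives > 100000 nM, again a limit.

All three compounds share a core and differ only in the group on the carbonyl carbon. Because every value sits at the limit of > 100000 nM in this assay, at which 3 of the 3 values shown sit, none of the steps between them can be read: a step that the two limits leave unreadable from compound 1 to compound 2, a step that the two limits leave unreadable from compound 1 to compound 3 and a step that the two limits leave unreadable from compound 2 to compound 3 are all hidden by the limits. Compound 3 therefore stands where the other two stand, at the top of what the assay can report, with no number of its own.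

Compound 4 `COc1ccc(-c2cnc(NC(=O)c3ccncc3)n2C)cc1` is the next compound, not yet measured. Its change from compound 3 is pyridin-4-yl in place of 4-methylphenyl on a carbonyl carbon. Among the measured compounds shown here, no measured step bears on it in a readable way, since every step so far is masked by the same limit; the only guide is that the piperidin-4-yl, 1,3-oxazol-5-yl and 4-methylphenyl variants were all tolerated up to the limit. Compound 4 is thus expected to show no step beyond the scatter, a step that the limit leaves unreadable from compound 3 to compound 4, and most likely to return a limit again. The estimate for compound 4 in this assay is 150000 nM, within 60000 nM to 400000 nM.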

Compound 4, half-maximal cytotoxic concentration: > 100000 nM
Compound 4: only a limit was reported (the forecaster's own chance of this, stated with the estimate: 85%); the middle value is on the limit's open side.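

No new step can be read for compound 4 against compound 1, compound 2 or compound 3, because all four compounds stand at the same limit of the assay: the limit of > 100000 nM in this assay, at which 4 of the 4 values shown sit.

The compounds shown leave open at what concentration, if any, these amides become toxic to the cells, and whether the four groups on the carbonyl carbon differ in this respect.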